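Aryloxy ketone variants of the acid series

The source may report more compounds than this note shows. Statements on the series, on what has been measured and on what is new or still open speak of the compounds shown alone.

Measured so far:
compound 1 `CC(C)[C@H](NC(=O)COc1cccc2ccccc12)C(=O)N[C@@H](CC(=O)O)C(=O)CSc1nnc(-c2ccccc2)o1` — 150000 nM
compound 2 `CC(C)[C@H](NC(=O)COc1cccc2ccccc12)C(=O)N[C@@H](CC(=O)O)C(=O)COc1nc2ccccc2[nH]1` — > 200000 nM
compound 3 `CC(C)[C@H](NC(=O)COc1cccc2ccccc12)C(=O)N[C@@H](CC(=O)O)C(=O)COc1ncnc2ccccc12` — > 200000 nM

Within the data shown here, in a functional assay on Jurkat cells (Homo sapiens) for inhibition (on this read-out lower numbers stand for stronger inhibition and higher numbers for weaker inhibition), compound 1 gives 150000 nM, the only plain number in the set. Compound 2 reaches only the assay limit, > 200000 nM. Compound 3 likewise stops at the limit, > 200000 nM. Both of these sit at the limit of > 200000 nM in this assay, at which 2 of the 3 values shown sit, so the steps of an at least 1.3-fold higher number from compound 1 to compound 2 (0.12 log units; that floor lies within the scatter) and an at least 1.3-fold higher number from compound 1 to compound 3 (0.12 log units; that floor lies within the scatter) carry floors that lie within the scatter; the step that the two limits leave unreadable from compound 2 to compound 3 cannot be read at all.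

Compound 4 `CC(C)[C@H](NC(=O)COc1cccc2ccccc12)C(=O)N[C@@H](CC(=O)O)C(=O)COc1cncc2ccccc12` is not yet measured. Its change from compound 1 is (isoquinolin-4-yl)oxy in place of (5-phenyl-1,3,4-oxadiazol-2-yl)sulfanyl on a saturated chain carbon bound to a carbonyl carbon. This is the same kind of move as the two steps already seen, in which the (5-phenyl-1,3,4-oxadiazol-2-yl)sulfanyl group was exchanged for an oxygen-linked bicyclic aromatic group, and both of those ended at the limit. The comparable step is therefore expected to run in the same direction, towards a higher number, with a fair chance that only a limit is reported; the expected step is a 1.7-fold higher number from compound 1 to compound 4 (0.22 log units; within the scatter). For compound 4 the estimate in this assay is 250000 nM, with a range from 120000 nM to 600000 nM.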

Compound 4, half-maximal inhibitory concentration: 166000 nM
For compound 4 the middle estimate is 1.5-fold (0.18 log units) above the measured one, within the range that was stated.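

In this assay, among these compounds, compound 4 is the only oxygen-linked bicyclic member of the set to return a plain number, and the exchange of (5-phenyl-1,3,4-oxadiazol-2-yl)sulfanyl for (isoquinolin-4-yl)oxy on this saturated chain carbon bound to a carbonyl carbon gives a 1.1-fold higher number from compound 1 to compound 4 (0.04 log units; within the scatter), so the sulfur-linked and oxygen-linked groups cannot be told apart on this pair. Against the other oxygen-linked groups, the readings are an at least 1.2-fold lower number from compound 3 to compound 4 (0.08 log units; that floor lies within the scatter) and an at least 1.2-fold lower number from compound 2 to compound 4 (0.08 log units; that floor lies within the scatter), and neither floor establishes a real difference among the three bicyclic groups. Both floors rest on limits rather than numbers: the limit of > 200000 nM in this assay, at which 2 of the 4 values shown sit.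

All of the readings lie close to that limit, so the compounds shown do not separate the groups at this position, and the step between compound 2 and compound 3 cannot be read. Going by these compounds, whether a simple phenoxy group or an amine on this saturated chain carbon, or a methyl ester in place of the carboxylic acid, would move the number beyond the scatter remains open.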